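Silyl-protected analogue of a fluorinated purine-type antiproliferative

The source may report more compounds than this note shows. Statements on the series, on what has been measured and on what is new or still open speak of the compounds shown alone.

Measured so far:
- compound 1 `CCC(CCO)n1cnc2c(Cl)nc(F)nc21`: 19800 nM
- compound 2 `CCC(CCO)n1cnc2c(Cl)ncnc21`: > 50000 nM
- compound 3 `CCCCCCCC[C@@H](CCO)n1cnc2c(Cl)ncnc21`: 2330 nM

All three compounds share one core and were tested in a functional assay on SW480 cells (Homo sapiens) for antiproliferative activity, read by MTT assay, with a stated time of 48 h; a lower number here means a stronger inhibitor, a higher number a weaker inhibitor. Compound 1 gives 19800 nM, the highest of the two plain numbers. Compound 2 reaches only a limit of the assay, > 50000 nM, and one such limit sits among the three values (the limit of > 50000 nM in this assay, at which 1 of the 3 values shown sits). Compound 3, which carries a longer chain and no fluoro, gives 2330 nM, a clearly lower number than compound 1.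

Going by the values given here, the one measured step that changes a single place, an at least 2.5-fold higher number from compound 1 to compound 2 (0.40 log units; beyond the scatter), concerns hydrogen in place of fluoro and so does not bear on the change now considered.

Compound 4 `CC(C)(C)[Si](C)(C)OCC(CCO)n1cnc2c(Cl)nc(F)nc21` differs from compound 1 by a group of 8 heavy atoms (6 carbon, 1 oxygen, 1 silicon; no ring) in place of one carbon atom, on a saturated chain carbon, two bonds along the chain from an aromatic nitrogen. The fluoro is kept. Among the compounds with values here, no measured step addresses a change at this chain position, so the expectation rests only on compound 1 and on the lower number seen for the larger compound 3. A modest drop in the number is expected, a 2.2-fold lower number from compound 1 to compound 4 (0.34 log units; beyond the scatter), though the uncertainty is wide. Compound 4 is estimated at 9000 nM, with a range from 2500 nM to 35000 nM.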

Compound 4, half-maximal inhibitory concentration: 8020 nM
Compound 4: the middle estimate sits 1.1-fold (0.05 log units) above what was measured, within the range that was stated.
By their numbers in this assay, from the lowest: compound 3; then compound 4; then compound 1. At a limit, above all of these: compound 2.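

In this assay, the step is a 2.5-fold lower number from compound 1 to compound 4 (0.39 log units; beyond the scatter). Placing a group of 8 heavy atoms (6 carbon, 1 oxygen, 1 silicon; no ring) in place of one carbon atom, on a saturated chain carbon, two bonds along the chain from an aromatic nitrogen, therefore does not cost activity: this much larger group gives a modestly lower number, so this position accepts a large change and can also shift the read-out while the fluoro stays in place. Nothing measured among these compounds explains why the number falls with this change.

The compounds shown leave open how the number would respond to other groups at this same chain carbon, such as a simple hydroxymethyl, an amine or a carboxylic acid, and so whether the silicon-bearing group itself matters or any larger group would do the same. They also leave open whether the same change would lower the number on a core without the fluoro, as in compound 2.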